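From Amide Back to Ester on a Shared Core

A few compounds are considered here, and "the series" means these few. Any claim that something is new, unique, unknown or untested is made for them only; others in the source may bear on it.

Measured compounds:
Compound 1, `CC1=C(C(=O)OC(C)(C)C)C(c2cccs2)NC(=O)N1`: 38%
Compound 2, `CCN(CC)C(=O)C1=C(C)NC(=O)NC1c1cccs1`: 22%

Both were tested in an assay on membranes from HEK293 cells for displacement of a labelled ligand from adenosine receptor A2b (Homo sapiens), read by scintillation counting, with a stated time of 30 min, tested at 1 uM; a higher number here means more inhibition at the concentration tested (going by the name of the read-out), a lower number less inhibition. Going by the values given here, compound 2 stands lowest of the two numbers, its nearest neighbour being compound 1, and the one measured step, a number 16 percentage points lower from compound 1 to compound 2 (beyond the scatter), separates them; that step put diethylamino in place of tert-butoxy on a carbonyl carbon. The unmeasured compound 3, `CC1=C(C(=O)OC2CCCC2)C(c2cccs2)NC(=O)N1`, arises from compound 2 by cyclopentyloxy in place of diethylamino on a carbonyl carbon. This change bears directly on the measured step because the group that leaves is the very diethylamino whose arrival in a number 16 percentage points lower from compound 1 to compound 2 (beyond the scatter) brought the modest fall, while the group that enters is, like tert-butoxy, joined through an oxygen to the carbonyl carbon. The step is therefore expected to run the other way and roughly undo that fall: a number 14 percentage points higher from compound 2 to compound 3 (beyond the scatter). Among the compounds with values here, compound 3 is thus expected to give about 36%, within a range of 20% to 55%, since only one step informs the guess.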

Compound 3, a percentage reported as inhibition, at one concentration (the size of the read-out at that concentration, not a potency): 1%
Compound 3: middle estimate off by 35 percentage points, on the high side; the measured number lies below the stated range.
By their numbers in this assay, from the lowest: compound 3; then compound 2; then compound 1.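

In this assay, an oxygen joined to the carbonyl carbon does not by itself restore the number: the step to cyclopentyloxy gives a number 21 percentage points lower from compound 2 to compound 3 (beyond the scatter), leaving this ester beneath the amide. With the oxygen kept, exchanging tert-butoxy for cyclopentyloxy on the same carbonyl carbon gives a number 37 percentage points lower from compound 1 to compound 3 (beyond the scatter), so the two esters are far from interchangeable here. No measurement available explains either fall.

On these data alone, it remains open whether the low number follows the ring of cyclopentyloxy specifically, and whether isopropoxy or cyclohexyloxy on the same carbonyl carbon would land nearer compound 1 or compound 3. With a single tested concentration, these numbers also leave the potency of all three compounds open.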